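Methoxy for Methyl on the Aryl Ring of Compound 2

The source may report more compounds than this note shows. Statements on the series, on what has been measured and on what is new or still open speak of the compounds shown alone.

Measured so far:
compound 1, `Cc1cc(NC(=O)Cn2nnc(-c3ccccc3F)n2)n(C2CCCCC2)n1`, gives 187 nM in an assay on HEK293 cells for activation of Kir3.1/Kir3.2 (Homo sapiens), read by thallium flux; a lower number here means that less compound is needed, a higher number that more compound is needed for the effect
compound 2, `Cc1cccc(-c2nnn(CC(=O)Nc3cc(C)nn3C3CCCCC3)n2)c1`, gives 129 nM in this assay

Compound 2 and compound 1 share a core and differ only in the aryl group on the tetrazole. Their numbers sit within the scatter of one another: the step of a 1.4-fold lower number from compound 1 to compound 2 (0.16 log units; within the scatter). Compound 2 is therefore not separated from compound 1 by anything this assay can resolve.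

Compound 3, `COc1cccc(-c2nnn(CC(=O)Nc3cc(C)nn3C3CCCCC3)n2)c1`, is not yet measured. It differs from compound 2 by methoxy in place of methyl on an aromatic carbon. Going by the values given here, the only measured step, from compound 1 to compound 2, exchanged one aryl group for another and stayed within the scatter, so the aryl ring appears to tolerate change without a large effect on this assay. A methoxy in place of a methyl at the same position is a smaller alteration than that exchange. Among the compounds with values here, no step that bears directly on methyl to methoxy has been measured.

The expectation for compound 3 is thus a number close to that of compound 2, with the step of a 1.2-fold higher number from compound 2 to compound 3 (0.07 log units; within the scatter) estimated to stay within the scatter. Compound 3 is estimated at 150 nM, within the range 60 nM to 400 nM.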

Compound 3, half-maximal effective concentration: 117 nM
Compound 3: middle estimate off by 1.3-fold (0.11 log units), on the high side, and the stated range covers the measured number.
By their numbers in this assay, from the lowest: compounds 3, 2 and 1 (each within the scatter of the next).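

In this assay, methoxy in place of methyl on the aromatic carbon meta to a large group gives a 1.1-fold lower number from compound 2 to compound 3 (0.04 log units; within the scatter) and thus stays within the scatter, even though the entering group brings an oxygen and a hydrogen-bond acceptor that the methyl lacks. The earlier step had exchanged one whole aryl group for another, whereas this one holds the place on the ring fixed and alters only the group there, and the exchange of 2-fluorophenyl for 3-methoxyphenyl gives a 1.6-fold lower number from compound 1 to compound 3 (0.20 log units; within the scatter) and so also stays within the scatter. The three aryl groups are therefore not separated by this measurement, and nothing available explains why their numbers lie so close together.

On these data alone, whether a hydroxyl, an amine or a carboxylic acid at this place would also stay within the scatter remains open, as does the effect of a longer chain such as ethoxy. The shared core is the same in all three compounds, so they also leave open how far the number depends on the rest of the molecule.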